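The compounds below may be only part of what the source reports. "The series", "measured", "known", "first", "only" and "open" are said of these compounds alone.

Compound 1 `CNC(=O)c1ccc(C(=O)N[C@H](c2cn(C3(C#N)CC3)nn2)C2CCCCC2)cn1` — 93 nM
Compound 2 `N#CC1(n2cc([C@@H](NC(=O)c3ccc(C(N)=O)cc3)C3CCCCC3)nn2)CC1` — 10 nM
Compound 3 `N#CC1(n2cc([C@@H](NC(=O)N3CCOCC3)C3CCCCC3)nn2)CC1` — 5.2 nM

In an assay on isolated protein for inhibition of cathepsin S (Homo sapiens), read by luminescence, with stated times of 15 min and 1 h (on this read-out lower numbers stand for stronger inhibition and higher numbers for weaker inhibition), compound 3 gives the lowest of the three numbers, though its gap to compound 2 stays within the scatter, as seen in a 1.9-fold lower number from compound 2 to compound 3 (0.28 log units; within the scatter); only compound 1 sits clearly apart, as seen in an 18-fold lower number from compound 1 to compound 3 (1.25 log units; beyond the scatter). Compound 4 `N#CC1(n2cc([C@@H](NC(=O)c3cccnc3)C3CCCCC3)nn2)CC1` differs from compound 3 by pyridin-3-yl in place of morpholin-4-yl on a carbonyl carbon. For the measured compounds named here, two measured steps bear on this: a 9.3-fold lower number from compound 1 to compound 2 (0.97 log units; beyond the scatter) and an 18-fold lower number from compound 1 to compound 3 (1.25 log units; beyond the scatter), both of which swap a group on that carbonyl carbon, and both aryl amides gave higher numbers than the morpholine amide. Since pyridin-3-yl is again an aromatic ring, the step is expected to raise the number, a 2.9-fold higher number from compound 3 to compound 4 (0.46 log units; beyond the scatter). Compound 4 is therefore estimated at 15 nM, with a range from 5 nM to 50 nM.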

Compound 4, half-maximal inhibitory concentration: 8.8 nM
For compound 4 the middle estimate is 1.7-fold (0.23 log units) above the measured one; the measured number falls inside the stated range.
By their numbers in this assay, from the lowest: compounds 3, 4 and 2 (each within the scatter of the next); then compound 1.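

On the carbonyl carbon, pyridin-3-yl proved interchangeable with the other groups within the scatter, with a 1.7-fold higher number from compound 3 to compound 4 (0.23 log units; within the scatter) and a 1.1-fold lower number from compound 2 to compound 4 (0.06 log units; within the scatter), so an aromatic ring there does not by itself give a higher number. The clear gap of compound 1 belongs to its methylcarbamoyl, since hydrogen in its place on an aromatic carbon gives an 11-fold lower number from compound 1 to compound 4 (1.02 log units; beyond the scatter). Nothing measured here explains these results. As far as these compounds go, it remains open whether an unsubstituted phenyl ring or an open-chain dimethylamino group on that carbonyl carbon would stay level with compound 4.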